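This account rests on a few compounds, and the source may have more. Where it says the series, first, only, none or still open, it means among the compounds named here.

Compound 3 `O=C(Nc1ccncc1)c1c(O)c2cccnc2n(-c2ccccc2)c1=O` gives 24.3% in a functional assay on the whole organism for inhibition, with Rattus norvegicus as the target, read by cytopathic effect and paw edema, at a dose of 100 mg/kg by the oral route; on this read-out lower numbers stand for less inhibition and higher numbers for more inhibition at the one dose given (going by the name of the read-out). Compound 1 `COc1cccc(NC(=O)c2c(O)c3cccnc3n(-c3ccccc3)c2=O)c1` gives 20.7%, a number within the scatter of compound 3, whereas compound 2 `O=C(Nc1cccc([N+](=O)[O-])c1)c1c(O)c2cccnc2n(-c2ccccc2)c1=O` gives 7.4%, clearly lower. Compound 4 `O=C(NCc1cccnc1)c1c(O)c2cccnc2n(-c2ccccc2)c1=O` differs from compound 3 in one place: (pyridin-3-yl)methyl in place of pyridin-4-yl on an amide-type nitrogen. The measured steps that bear on this are the two earlier changes on the same amide-type nitrogen, a number 3.6 percentage points higher from compound 1 to compound 3 (within the scatter) and a number 16.9 percentage points higher from compound 2 to compound 3 (beyond the scatter), neither of which involves a (pyridin-3-yl)methyl group, so they offer only a loose guide. Nothing in these numbers points to a large shift, and the step expected here, a number 4.3 percentage points lower from compound 3 to compound 4 (within the scatter), is small and within the scatter. Compound 4 is therefore estimated at 20%, with a range from 5% to 35%.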

Compound 4, a percentage reported as inhibition, in the whole organism at one dose (the size of the read-out at that dose, not a potency): 14.7%
Estimate against measurement, compound 4: 5.3 percentage points above, within the range that was stated.
By their numbers in this assay, from the lowest: compounds 2, 4, 1 and 3 (each within the scatter of the next, the first and the last beyond it).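

In this assay, (pyridin-3-yl)methyl on the amide-type nitrogen gives steps within the scatter against all three earlier groups: a number 9.6 percentage points lower from compound 3 to compound 4 (within the scatter), a number 6 percentage points lower from compound 1 to compound 4 (within the scatter) and a number 7.3 percentage points higher from compound 2 to compound 4 (within the scatter). Compound 4 therefore falls within the scatter of both compound 2 and compound 3, although those two lie beyond the scatter of each other. Nothing measured here explains these steps.

From the compounds shown here alone, this one step changes both the pyridine attachment and the chain, so their separate contributions remain open. Also open, going by these compounds, is how a (pyridin-3-yl)ethyl group or a morpholine on this nitrogen would read.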